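Lactone series: methoxyphenyl for hydroxyphenyl, cytotoxicity outlook

The source may report more compounds than this note shows. Statements on the series, on what has been measured and on what is new or still open speak of the compounds shown alone.

Working notes on two measured lactones and one open analogue. In a functional assay on HL-60 cells (Homo sapiens) for cytotoxicity, read by WST assay, with a stated time of 48 h (a lower number here means that less compound is needed, a higher number that more compound is needed for the effect), compound 2 `O=C1OC[C@H](Cc2ccccc2O)[C@H]1Cc1ccc(Cl)c(Cl)c1` gives 33000 nM. Compound 1 `COc1cccc(C[C@H]2C(=O)OC[C@@H]2Cc2ccccc2)c1` gives 66000 nM in this assay, and the gap between compound 1 and compound 2 lies within the usual scatter, so neither can be placed above the other. For the measured compounds named here, no pair of measured compounds differing in a single place is available, so nothing in hand shows what a change at one position is worth in this assay. Compound 3 `COc1ccc(C[C@H]2COC(=O)[C@@H]2Cc2ccc(Cl)c(Cl)c2)cc1` is not yet measured. It differs from compound 2 as follows: 4-methoxyphenyl in place of 2-hydroxyphenyl on a saturated chain carbon bound to a saturated ring carbon. Going by the values given here, with no comparable step to rest on, the expected change in this assay is none beyond the scatter, in either direction. The estimate for compound 3 in this assay is 40000 nM, within a range from 12000 nM to 130000 nM. That estimate means an expected step of a 1.2-fold higher number from compound 2 to compound 3 (0.08 log units; within the scatter).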

Compound 3, half-maximal effective concentration: 37000 nM
Beside the measured number, compound 3's estimate is 1.1-fold (0.03 log units) above it, and the stated range covers the measured number.
By their numbers in this assay, from the lowest: compounds 2, 3 and 1 (each within the scatter of the next).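

In this assay, the series now has its first comparison at a single place: a 1.1-fold higher number from compound 2 to compound 3 (0.05 log units; within the scatter). On a saturated chain carbon bound to a saturated ring carbon, 4-methoxyphenyl therefore replaces 2-hydroxyphenyl without a readable change, even with 0 hydrogen-bond donors in place of 1 hydrogen-bond donor. No measured information bearing on this result is available.

This single step alters both the oxygen substituent and its location on the aromatic ring, so the contribution of each remains unresolved. Also open, going by these compounds, is whether a phenyl group carrying an amine or a carboxylic acid, or a longer chain at the same place, would produce a step beyond the scatter in this assay.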